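Isopropyl to tert-butyl on the piperidine of an oral urea amide

The source may report more compounds than this note shows. Statements on the series, on what has been measured and on what is new or still open speak of the compounds shown alone.

Measured so far:
compound 1 `CC(C)N1CCC(Oc2ccc(C(=O)Nc3ccc(NC(=O)Nc4cc(C(C)(C)C)on4)cc3)nc2)CC1`, 1820 ng.h/mL
compound 2 `CC(C)(C)c1cc(NC(=O)Nc2ccc(NC(=O)c3cc(OC4CCNCC4)ccn3)cc2)no1`, 191 ng.h/mL

Within the data shown here, in an ADME assay on the whole organism (plasma, strain Sprague-Dawley) for pharmacokinetics, with Rattus norvegicus as the target, read by LC-MS, at a dose of 10 mg/kg by the oral route (on this read-out lower numbers stand for lower exposure and higher numbers for higher exposure at the dose given), compound 1 gives 1820 ng.h/mL, the higher of the two numbers; compound 2 gives 191 ng.h/mL, a gap that lies beyond the scatter, though the two compounds differ in more than one place and no single step between them is drawn.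

Compound 3 `CC(C)(C)c1cc(NC(=O)Nc2ccc(NC(=O)c3ccc(OC4CCN(C(C)(C)C)CC4)cn3)cc2)no1` has not been measured. It differs from compound 1 only in the group on the piperidine nitrogen: methyl in place of hydrogen on a saturated chain carbon bound to an amine nitrogen in a ring and two saturated chain carbons. Among the measured compounds shown here, no step between measured compounds bears on this change, so the expectation rests on compound 1 alone. The addition is small, and compound 3 is expected to stay close to compound 1, with a step of a 1.2-fold lower number from compound 1 to compound 3 (0.08 log units; within the scatter) that is not beyond the scatter. Compound 3 is thus estimated at 1500 ng.h/mL, within a range of 600 ng.h/mL to 4000 ng.h/mL.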

Compound 3, area under the concentration-time curve: 2670 ng.h/mL
Compound 3: the middle estimate sits 1.8-fold (0.25 log units) below what was measured; the measured number falls inside the stated range.
By their numbers in this assay, from the lowest: compound 2; then compounds 1 and 3 (each within the scatter of the next).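

In this assay the change from isopropyl to tert-butyl on the piperidine nitrogen gives a 1.5-fold higher number from compound 1 to compound 3 (0.17 log units; within the scatter) and so leaves the exposure of compound 1 and compound 3 level within the scatter. Among these compounds, this is the first step at this position that can be read on its own, as compound 1 and compound 2 differ in more than one place. Nothing measured here accounts for this outcome.

Still open, on these data alone, is whether other groups on the piperidine nitrogen, such as a cyclopropyl ring, a 2-hydroxyethyl chain or an acetyl group, would stay level with compound 1 and compound 3 in this assay as well. Also open, as far as these compounds go, is how much of the gap to compound 2 belongs to the group on the piperidine nitrogen; that pair differs in more than one place.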